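A few compounds are considered here, and "the series" means these few. Any claim that something is new, unique, unknown or untested is made for them only; others in the source may bear on it.

Compound 2 `Cc1nn(-c2nc(-c3ccc(Cl)c(Cl)c3)c(SC(C)C)s2)c(C(=O)O)c1-c1cnccn1` gives the highest of the two numbers measured in a functional assay on BJAB cells (Homo sapiens) for antiproliferative activity, with a stated time of 4 days (a higher number here means that more compound is needed for the effect, a lower number that less compound is needed), namely 14000 nM. Its nearest neighbour is compound 1 `Cc1ccc(-c2c(C)nn(-c3nc(-c4ccc(Cl)c(Cl)c4)c(SC(C)C)s3)c2C(=O)O)cc1`, which in this assay gives 3800 nM. The two differ in one place, where the pyrazin-2-yl group of compound 2 replaces a 4-methylphenyl group, and that step a 3.7-fold higher number from compound 1 to compound 2 (0.57 log units; beyond the scatter).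

Compound 3 `Cc1cccc(-c2c(C)nn(-c3nc(-c4ccc(Cl)c(Cl)c4)c(SC(C)C)s3)c2C(=O)O)c1` has not yet been measured in this assay. It differs from compound 2 in the same place: 3-methylphenyl in place of pyrazin-2-yl on an aromatic carbon. Among the compounds with values here, this change runs in the opposite sense to the one step already measured, since a ring of carbon only with a methyl group again takes the place of the ring with two nitrogen atoms. Within the data shown here, the position of the methyl group on that ring, however, is not the same as in compound 1, and no measured pair shows what this difference alone does.

Because the step from compound 1 to compound 2 a 3.7-fold higher number from compound 1 to compound 2 (0.57 log units; beyond the scatter) was beyond the scatter, the number for compound 3 is expected to move back downward by a similar amount, a 3.1-fold lower number from compound 2 to compound 3 (0.49 log units; beyond the scatter). Compound 3 is therefore estimated at 4500 nM, with a range from 1500 nM to 13000 nM.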

Compound 3, half-maximal effective concentration: 17000 nM
Estimate against measurement, compound 3: 3.8-fold (0.58 log units) below, and the stated range ends below it.
By their numbers in this assay, from the lowest: compound 1; then compounds 2 and 3 (each within the scatter of the next).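

Replacing pyrazin-2-yl with 3-methylphenyl leaves the number in this assay effectively unchanged, with a 1.2-fold higher number from compound 2 to compound 3 (0.08 log units; within the scatter), even though a ring of carbon only enters in place of one with two nitrogen atoms. The earlier step from compound 1 to compound 2 therefore cannot be read simply as a loss caused by swapping a carbon ring for a nitrogen-containing one, since compound 3 has no ring nitrogen on this group and still sits with compound 2. The new comparison instead shows that the place of the methyl group on the phenyl ring matters here, with a 4.5-fold higher number from compound 1 to compound 3 (0.65 log units; beyond the scatter), so that among these three compounds only the one carrying 4-methylphenyl stands apart. Nothing available explains why moving one methyl group changes the number in this way.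

Going by these compounds, it remains open whether a plain phenyl ring would sit with compound 1 or with compounds 2 and 3. On these data alone, it is equally open whether a methoxy group, a chlorine atom or an amine in place of the methyl group on the ring would follow the same dependence on position.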